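The source may report more compounds than this note shows. Statements on the series, on what has been measured and on what is new or still open speak of the compounds shown alone.

Working notes on the series. In a functional assay on NCI-H23 cells (Homo sapiens) for inhibition, with a stated time of 48 h (on this read-out lower numbers stand for higher toxicity in this test and higher numbers for lower toxicity in this test), compound 1 `COc1ccc(N(CC(=O)NCCC[Te]c2ccccc2)C(=O)CNC(=O)OC(C)(C)C)cc1` reaches only a limit of < 100000 nM, so its standing rests on that limit and not on a number. Two further members carry numbers: compound 2 `COc1ccc(N(CC(=O)NCCC[Te]c2ccccc2)C(=O)CCSC2=C(C)C(=O)c3ccccc3C2=O)cc1` gives 20400 nM in this assay, and compound 3 `CC1=C(SCCC(=O)OCC(=O)NCCC[Te]c2ccccc2)C(=O)c2ccccc2C1=O` gives 44700 nM. Among the compounds with values here, no step between measured compounds that differ in a single place is available; the only guide for compound 1 is the limit of < 100000 nM in this assay, at which 1 of the 3 values shown sits. Compound 4 `COc1ccc(N(CC(=O)NCCC[Te]c2ccccc2)C(=O)c2ccccc2)cc1` differs from compound 1 by phenyl in place of ((tert-butoxycarbonyl)amino)methyl on a carbonyl carbon. For this change a small shift toward lower numbers in this assay is expected, not clearly beyond the scatter. Compound 4 is estimated at 50000 nM, within 15000 nM to 100000 nM. The implied step that the limit leaves unreadable from compound 1 to compound 4 is an expectation only.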

Compound 4, concentration lethal to 50% of the cells: < 100000 nM
Compound 4 was reported as a limit; the forecaster's own chance of this, stated with the estimate: 35%; the middle value is on the limit's open side.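

Within the data shown here, compound 1 and compound 4 both stand only as limits in this assay, so no step between them can be read: the limit of < 100000 nM in this assay, at which 2 of the 4 values shown sit. The compounds shown leave open how far phenyl and ((tert-butoxycarbonyl)amino)methyl on a carbonyl carbon differ on this read-out.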